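A few compounds are considered here, and "the series" means these few. Any claim that something is new, unique, unknown or untested is made for them only; others in the source may bear on it.

Measured so far in a functional assay on Hep 3B2 cells (Homo sapiens) for inhibition, read by sulforhodamine B assay, with a stated time of 72 h; on this read-out higher numbers stand for weaker inhibition and lower numbers for stronger inhibition:
- Compound 1 `C[C@H](Nc1ncnc2[nH]cnc12)c1nn(-c2cccnc2)c2ccc(F)cc12`: 40100 nM
- Compound 2 `C[C@H](Nc1ncnc2[nH]cnc12)c1nn(-c2cccc(F)c2)c2cc(F)ccc12`: > 40000 nM, a limit of the assay
- Compound 3 `C[C@H](Nc1ncnc2[nH]cnc12)c1nn(-c2ccc(C#N)cc2)c2cc(F)ccc12`: 13500 nM

Of the two true numbers, compound 1 gives 40100 nM and compound 3 gives 13500 nM. The gap between these two lies beyond the scatter, with compound 3 the lower.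

Compound 4 `C[C@H](Nc1ncnc2[nH]cnc12)c1nn(-c2cccc(S(C)(=O)=O)c2)c2cc(F)ccc12` carries 3-(methylsulfonyl)phenyl in place of 4-cyanophenyl on an aromatic nitrogen.

For the measured compounds named here, one measured step bears on this place, an at least 2.9-fold lower number from compound 2 to compound 3 (0.47 log units; beyond the scatter), and it starts from a limit, so its true size is open. Leaving the 4-cyanophenyl may give back part of that step, so a modest rise in this assay is expected. The expected change is a 1.8-fold higher number from compound 3 to compound 4 (0.25 log units; within the scatter). Compound 4 is estimated at 24000 nM, with an expected range of 10000 nM to 55000 nM.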

Compound 4, half-maximal inhibitory concentration: 13000 nM
Beside the measured number, compound 4's estimate is 1.8-fold (0.27 log units) above it; low and high end bracket the measured number.
By their numbers in this assay, from the lowest: compounds 4 and 3 (each within the scatter of the next); then compound 1.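

In this assay, swapping 4-cyanophenyl for 3-(methylsulfonyl)phenyl on the aromatic nitrogen leaves the number unchanged within the scatter: a 1.0-fold lower number from compound 3 to compound 4 (0.02 log units; within the scatter). The nitrile is therefore not required at this position, since methylsulfonyl in place of fluoro also gives an at least 3.0-fold lower number from compound 2 to compound 4 (0.48 log units; beyond the scatter). Compound 2 stands at a limit of the assay, and the true size of this step stays open because of that limit: the limit of > 40000 nM in this assay, at which 1 of the 4 values shown sits.

As far as these compounds go, it remains open whether an amine or a carboxylic acid in place of methylsulfonyl on this phenyl ring would shift the number beyond the scatter.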